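The compounds below may be only part of what the source reports. "The series", "measured", "known", "first", "only" and "open" are said of these compounds alone.

Working notes on the series.

Compound 1 `CCCCN(CCC)c1nc(C)nc2c(-c3c(C)cc(N(C)C)nc3C)c(C)nn12` gives 12.8 nM in an assay on cell membranes for displacement of a labelled ligand from corticotropin-releasing factor receptor 1 (Rattus norvegicus); a lower number here means a stronger inhibitor, a higher number a weaker inhibitor. Among the three measured compounds this is the highest number: compound 2 `CCCN(CCC)c1nc(C)nc2c(-c3ccc(OC)nc3C)c(C)nn12` gives 5.7 nM, and compound 3 `CCC[C@H](C)Nc1nc(C)nc2c(-c3ccc(OC)nc3C)c(C)nn12` gives 4.5 nM. Both gaps from compound 1 are beyond the scatter; the gap between compound 2 and compound 3 is not.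

Compound 4 `COCCNc1nc(C)nc2c(-c3c(C)cc(N(C)C)nc3C)c(C)nn12` is not yet measured. It differs from compound 1 in one place: (2-methoxyethyl)amino in place of butyl(propyl)amino on an aromatic carbon.

Within the data shown here, only one measured step bears on this change, and only loosely. From compound 2 to compound 3 the dialkylamino group becomes a monoalkylamino group carrying one hydrogen-bond donor, and the result is a 1.3-fold lower number from compound 2 to compound 3 (0.10 log units; within the scatter). That step shows the loss of one alkyl branch at this position is tolerated. Among the measured compounds shown here, the change to compound 4 goes further: the remaining chain is shorter and ends in a methoxy group, and no measured pair covers that. The step from compound 1 to compound 4 is therefore expected to be modest, and, with no direct support for a gain, the estimated number for compound 4 is somewhat higher than that of compound 1, as in a 2.3-fold higher number from compound 1 to compound 4 (0.37 log units; beyond the scatter).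

Compound 4 is estimated at 30 nM, with a range of 10 nM to 100 nM.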

Compound 4, half-maximal inhibitory concentration: > 10000 nM
Compound 4 gave a limit, no number; the forecaster's own chance of this, stated with the estimate: 3%; middle value at least 330-fold (2.52 log units) from the limit.
By their numbers in this assay, from the lowest: compounds 3 and 2 (each within the scatter of the next); then compound 1. At a limit, above all of these: compound 4.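

In this assay compound 4 gives > 10000 nM, which is a limit of the assay and not a number. At this aromatic carbon between two ring nitrogen atoms, (2-methoxyethyl)amino in place of butyl(propyl)amino gives an at least 780-fold higher number from compound 1 to compound 4 (2.89 log units; beyond the scatter), so this position does not accept every amino substituent, and the earlier tolerance of (1-methylbutyl)amino in place of dipropylamino, seen on a different aryl group, does not extend to all monoalkylamino groups. The step is a lower bound on the loss, not a measured gap: the limit of > 10000 nM in this assay, at which 1 of the 4 values shown sits.

The compounds shown do not separate the three things that change together in this step: the shorter chain, the ether oxygen and the amino hydrogen. A plain propylamino or pentylamino chain, a (3-methoxypropyl)amino group, or a tertiary amine such as (2-methoxyethyl)(propyl)amino on the core of compound 1 would each isolate one of these, and (1-methylbutyl)amino on that same core would show whether the earlier tolerance carries over to this aryl group.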